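The source may report more compounds than this note shows. Statements on the series, on what has been measured and on what is new or still open speak of the compounds shown alone.

Measured so far:
- compound 1, `CC1(C)Cc2c(sc(NC(=O)Nc3ccc(Cl)cc3)c2C(N)=O)C(C)(C)N1`, gives 1240 nM
- compound 2, `CCC1CCc2c(sc(NC(=O)Nc3ccc(Cl)cc3)c2C(N)=O)C1`, gives only a limit, > 25000 nM
- compound 3, `CCN1CCc2c(sc(NC=O)c2C(N)=O)C1`, gives only a limit, > 25000 nM

In a functional assay (strain AB) with Danio rerio as the target, read by microscopy, with a stated time of 1 h (on this read-out lower numbers stand for an effect already at smaller amounts and higher numbers for an effect only at larger amounts of compound), compound 2 stands at the limit of the read-out rather than at a number. Two of the three values shown sit at that limit (the limit of > 25000 nM in this assay, at which 2 of the 3 values shown sit). Going by the values given here, no step between measured compounds is at hand, so no measured size of change can be read from the series.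

Compound 4, `C[N+](C)(C)C1CCc2c(sc(NC(=O)Nc3ccc(Cl)cc3)c2C(N)=O)C1`, differs from compound 2 by a group of 4 heavy atoms (3 carbon, 1 nitrogen; no ring) in place of a group of 2 heavy atoms (2 carbon; no ring), on a saturated ring carbon. With compound 2 already at the limit, the expected step that the limit leaves unreadable from compound 2 to compound 4 is none beyond the scatter, and a limit again is the likely read-out. Compound 4 is estimated at 30000 nM, with a range from 8000 nM to 100000 nM.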

Compound 4, half-maximal effective concentration: 5870 nM
Compound 4: the middle estimate sits 5.1-fold (0.71 log units) above what was measured, outside the stated range (below it).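

In this assay, the saturated ring carbon proves to be a place where exchanging ethyl for a group of net charge +1 moves the read-out, with an at least 4.2-fold lower number from compound 2 to compound 4 (0.62 log units; beyond the scatter). Going by these compounds alone, this is the first measured size of change. Compound 2 is only a limit, so this step gives a minimum size: the limit of > 25000 nM in this assay, at which 2 of the 4 values shown sit.

As far as these compounds go, whether the lower number goes with the net charge or with the larger group stays open. A neutral dimethylamino group on the same ring carbon would separate the two, and a carboxylic acid there would test the opposite charge.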